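Side-chain amine exchange, from compound 1 to compound 3

The source may hold more compounds than are shown below. What is called first, only, known or untested is meant among the compounds shown, and "the series" means these compounds.

Measured so far:
compound 1 `CN(C)CCCOc1ccccc1/C=C/c1ccccc1`: 14.2%
compound 2 `CN1CCN(CCCCOc2ccccc2/C=C/c2ccccc2F)CC1`: 0%

Two compounds have numbers in a functional assay on the whole organism with Mus musculus as the target, in the maximal electroshock model, at a dose of 50 mg/kg by the oral route; on this read-out higher numbers stand for more inhibition at the one dose given (going by the name of the read-out) and lower numbers for less inhibition. Compound 1 `CN(C)CCCOc1ccccc1/C=C/c1ccccc1` gives 14.2% in this assay, the higher of the two. Compound 2 `CN1CCN(CCCCOc2ccccc2/C=C/c2ccccc2F)CC1` gives 0% in this assay, and the gap between the two lies beyond the scatter. Going by the values given here, no pair of measured compounds differs in a single place, so no measured step is available to anchor the next change.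

Compound 3 `OCC1CCCN(CCCCOc2ccccc2/C=C/c2ccccc2)C1` is the next to be measured. Relative to compound 1 the change is (3-(hydroxymethyl)piperidin-1-yl)methyl in place of dimethylamino on a saturated chain carbon, three bonds along the chain from an oxygen on an aromatic ring. Among the compounds with values here, with no measured step, the direction can only be read from the two values at hand: the one compound whose amine is not the dimethylamino of compound 1, compound 2, sits at the low end, though it differs in other places as well. The expected step is a number 6.2 percentage points lower from compound 1 to compound 3 (within the scatter), a small drop that stays within the scatter. Compound 3 is therefore expected to give about 8%, with a likely range from 0% to 25%.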

Compound 3, a percentage reported as inhibition, in the whole organism at one dose (the size of the read-out at that dose, not a potency): 12.5%
The estimate for compound 3 lay 4.5 percentage points below the measured number; low and high end bracket the measured number.
By their numbers in this assay, from the lowest: compound 2; then compounds 3 and 1 (each within the scatter of the next).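

In this assay, going by these compounds alone, (3-(hydroxymethyl)piperidin-1-yl)methyl in place of dimethylamino on a saturated chain carbon, three bonds along the chain from an oxygen on an aromatic ring, gives a number 1.7 percentage points lower from compound 1 to compound 3 (within the scatter), the first measured step. At this position, then, 9 heavy atoms in place of 3, with one six-membered non-aromatic ring and 1 hydrogen-bond donor entering, leave two numbers that cannot be told apart at the one dose given. No measurement at hand accounts for this result.

Still open, going by these compounds, is what the ring and the hydroxymethyl each contribute, since the exchange brings in both at once, and a plain piperidine or a morpholine on the same chain would begin to separate them. Also open, on these data alone, is whether a group of another kind at this place, such as a carboxylic acid, would move the number beyond the scatter in this assay.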